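Replacing fluoro with methoxy on the aromatic ring

The compounds below may be only part of what the source reports. "The series", "measured", "known", "first", "only" and "open" are said of these compounds alone.

Compound 1 `CC1(C)CC12NC(=O)N(NC(=O)c1ccccc1)C2=O` gives 300 mg/kg in a functional assay on the whole organism (Hindlimb) for inhibition, with Mus musculus as the target, with a stated time of 0.5 h; a lower number here means that less compound is needed, a higher number that more compound is needed for the effect.
Compound 2 `CC1(C)CC12NC(=O)N(NC(=O)c1ccc(Br)cc1)C2=O` gives 300 mg/kg in this assay.
Compound 3 `CC1(C)CC12NC(=O)N(NC(=O)c1ccc(F)cc1)C2=O` gives 100 mg/kg in this assay.

Among these three, compound 3 needs the smallest dose: its step to compound 1 and its step to compound 2 both lie beyond the scatter, so it stands alone at the low end. The step from compound 1 to compound 3 was a 3.0-fold lower number from compound 1 to compound 3 (0.48 log units; beyond the scatter), and the step from compound 2 to compound 3 was a 3.0-fold lower number from compound 2 to compound 3 (0.48 log units; beyond the scatter), whereas the step from compound 1 to compound 2 was no change at the digits printed from compound 1 to compound 2 (within the scatter).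

Compound 4 `COc1ccc(C(=O)NN2C(=O)NC3(CC3(C)C)C2=O)cc1` is the next member. The change is methoxy in place of fluoro on an aromatic carbon. Within the data shown here, no measured step involves a methoxy group, so none bears directly on this change. What the data show is that the fluoro group alone gave the lower dose, while hydrogen and bromo at the same position gave the same higher dose. On that basis the expected outcome for compound 4 is a modest rise in dose back toward the level of compound 1 and compound 2, with a step of a 2.0-fold higher number from compound 3 to compound 4 (0.30 log units; within the scatter). The estimate for compound 4 is 200 mg/kg, with a range from 100 mg/kg to 600 mg/kg.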

Compound 4, minimum effective dose: 100 mg/kg
For compound 4 the middle estimate is 2.0-fold (0.30 log units) above the measured one; the measured number falls inside the stated range.
By their numbers in this assay, from the lowest: compounds 3 and 4 (each within the scatter of the next); then compounds 1 and 2 (each within the scatter of the next).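

Methoxy can take the place of fluoro on this aromatic carbon, para to a large group, without a visible loss in this assay, with no change at the digits printed from compound 3 to compound 4 (within the scatter) as the step between them, so the lower dose no longer belongs to fluoro alone. Methoxy also stands apart from the two groups at the higher dose, with a 3.0-fold lower number from compound 1 to compound 4 (0.48 log units; beyond the scatter) in the comparison with hydrogen and a 3.0-fold lower number from compound 2 to compound 4 (0.48 log units; beyond the scatter) in the comparison with bromo, which shows that the choice of group at this position can separate these compounds, although compound 2 shows that a group in place of hydrogen does not always lower the dose. Nothing available explains why fluoro and methoxy fall together while hydrogen and bromo fall apart from them.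

The compounds shown leave open whether an amine, a carboxylic acid or a longer chain such as ethoxy at this position would keep the lower dose or return it to the higher level. They also leave open whether fluoro and methoxy would stay level at another place on the ring.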